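Halogen swap on the triazolyl phenyl ring, two cores

The source may report more compounds than this note shows. Statements on the series, on what has been measured and on what is new or still open speak of the compounds shown alone.

Measured so far in a functional assay on SMMC-7721 cells (Homo sapiens) for cytotoxicity, read by MTT assay, with a stated time of 4 days; on this read-out lower numbers stand for stronger inhibition and higher numbers for weaker inhibition:
- compound 1 `C=C1C[C@]23C[C@@]1(O)CC[C@H]2c1ccc(OS(=O)(=O)c2ccc(C)cc2)c(C)c1[C@@H]3Cn1cc(-c2ccc(Cl)cc2)nn1`: > 20000 nM (a limit)
- compound 2 `C=C1C(=O)[C@]23C[C@@]1(O)CC[C@H]2c1ccc(OS(=O)(=O)c2ccc(C)cc2)c(C)c1[C@@H]3Cn1cc(-c2ccc(Br)cc2)nn1`: 4320 nM
- compound 3 `C=C1C[C@]23C[C@@]1(O)CC[C@H]2c1ccc(OS(=O)(=O)c2ccc(C)cc2)c(C)c1[C@@H]3Cn1cc(-c2ccc(Br)cc2)nn1`: > 20000 nM (a limit)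

Two cores carry the same side chain. Compound 3 and compound 1 share one core; compound 2 carries the other, and the difference between the two cores is not broken down here. Compound 2 is the only one of the three that gives a number in this assay. For compound 1 the value is a limit of the assay, not a number. For compound 3 the value likewise is a limit. The change from compound 3 to compound 1 is chloro in place of bromo on an aromatic carbon; its step that the two limits leave unreadable from compound 3 to compound 1 cannot be read, due to the limit of > 20000 nM in this assay, at which 2 of the 3 values shown sit.

Compound 4 `C=C1C(=O)[C@]23C[C@@]1(O)CC[C@H]2c1ccc(OS(=O)(=O)c2ccc(C)cc2)c(C)c1[C@@H]3Cn1cc(-c2ccc(Cl)cc2)nn1` is not yet measured. It is made from compound 2 by chloro in place of bromo on an aromatic carbon, the same change as from compound 3 to compound 1, at a place described in the same words. Among the measured compounds shown here, the only measured instance of this change gives no readable size, so there is no measured basis for expecting a shift in either direction; the expectation for compound 4 therefore rests on compound 2 and its value 4320 nM alone. The step from compound 2 to compound 4 is expected to be about a 1.2-fold higher number from compound 2 to compound 4 (0.06 log units; within the scatter). For compound 4 the estimate in this assay is 5000 nM, expected to fall between 2000 nM and 15000 nM.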

Compound 4, half-maximal inhibitory concentration: 6180 nM
Estimate against measurement, compound 4: 1.2-fold (0.09 log units) below, within the range that was stated.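

In this assay, on the core of compound 2, chloro in place of bromo on an aromatic carbon, para to a large group, gives a 1.4-fold higher number from compound 2 to compound 4 (0.16 log units; within the scatter), so on this core the exchange of 4-bromophenyl for 4-chlorophenyl leaves the read-out within the scatter. On the core of compound 1, the step from compound 3 to compound 1 cannot be read, because both values are limits and not numbers: the limit of > 20000 nM in this assay, at which 2 of the 4 values shown sit.

The series therefore shows the size of this change on one core only, and it does not show whether that size carries over to the other core, since one readable step gives nothing to compare it with.

The compounds shown cover only bromo and chloro at this place, which leaves open how fluoro, methoxy or nitrile on the same phenyl ring would read on the core of compound 2. Also open, going by these compounds, is whether a group of another kind at this place, such as an amine or a carboxylic acid, would give a number rather than a limit on the core of compound 1.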